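A Small Swap on Compound 2: tert-Butyl to Methylsulfanyl

The source may hold more compounds than are shown below. What is called first, only, known or untested is meant among the compounds shown, and "the series" means these compounds.

Of the compounds shown here, three have been measured in a functional assay on MLM cells (Homo sapiens) for cytotoxicity, using microsomes; on this read-out higher numbers stand for an effect only at larger amounts of compound and lower numbers for an effect already at smaller amounts. Compound 1 `COC(=O)C(Cc1cc(OC)c(OC)c(OC)c1)c1ccc(OC)cc1` reaches only the limit of this assay, > 25 uM. Compound 2 `COc1cc(/C=C/c2ccc(C(C)(C)C)cc2)cc(OC)c1OC` likewise gives no number in this assay but only the limit > 25 uM. Among the measured compounds shown here, compound 3 `COc1cc(/C=C\c2ccc(C(C)C)cc2)cc(OC)c1OC` is the one member with a measured value in this assay, 7 uM. Compound 2 thus stands at the limit, a position it shares with one further value, as summarised by the limit of > 25 uM in this assay, at which 2 of the 3 values shown sit. For the measured compounds named here, no pair among the measured compounds differs in a single place, so no measured step can be drawn from them.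

Compound 4 `COc1cc(/C=C/c2ccc(SC)cc2)cc(OC)c1OC` is not yet measured. It differs from compound 2 by methylsulfanyl in place of tert-butyl on an aromatic carbon. Since compound 2 sits at a limit, the step from compound 2 to compound 4 in this assay can only be bounded at its start. The expected change is a modest shift toward an effect at smaller amounts, an at least 1.2-fold lower number from compound 2 to compound 4 (0.09 log units; that floor lies within the scatter), not clearly beyond the scatter. For compound 4 the estimate in this assay is 20 uM, with a range from 5 uM to 50 uM.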

Compound 4, concentration for half-maximal effect: 7.3 uM
Compound 4: middle estimate off by 2.7-fold (0.44 log units), on the high side, within the range that was stated.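

Among the compounds shown here, this change gives the first single-place reading: an at least 3.4-fold lower number from compound 2 to compound 4 (0.53 log units; beyond the scatter) in this assay. For the compounds shown here, it shows that the group on this aromatic carbon, para to a large group, can by itself move the read-out, which the earlier compounds could not show with no single-place pair among them. The printed step is only a floor because compound 2 stands at a limit of the assay rather than at a number: the limit of > 25 uM in this assay, at which 2 of the 4 values shown sit.

Going by these compounds, how large the true step is therefore stays open, as does whether the change comes from losing tert-butyl or from gaining methylsulfanyl. The compounds shown also leave open how an amine, a carboxylic acid or a longer chain would read on the same aromatic carbon of the shared core.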